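The source may report more compounds than this note shows. Statements on the series, on what has been measured and on what is new or still open speak of the compounds shown alone.

Measured compounds:
compound 1, `Cc1cc(/C=C/C#N)cc(C)c1Oc1cc(Nc2ccc(C#N)cc2)c(N)cc1C(=O)NN`, in a physicochemical assay for lipophilicity, read by HPLC, measured as octanol-water partition, with a stated time of 24 h, at pH 7.4 (a higher number here means a more lipophilic compound, a lower number a more polar compound), compound 1 gives 2.31
compound 2, `Cc1cc(/C=C/C#N)cc(C)c1Oc1cc(Nc2ccc(C#N)cc2)c(N)cc1C(=O)NCCCO`, in this assay compound 2 gives 3.22

Compound 2 is the more lipophilic of the two measured compounds: the step of a number 0.91 log units higher from compound 1 to compound 2 (beyond the scatter) lies beyond the scatter, so compound 2 stands clearly above compound 1.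

The next compound, compound 3, has the structure `Cc1cc(/C=C/C#N)cc(C)c1Oc1cc(Nc2ccc(C#N)cc2)c(N)cc1C(=O)NCCC(F)F`. It differs from compound 2 in one place: difluoromethyl in place of hydroxymethyl on a saturated chain carbon, two bonds along the chain from an amide-type nitrogen.

Among the measured compounds shown here, no measured step carries this same change. For the measured compounds named here, the one step that is known, a number 0.91 log units higher from compound 1 to compound 2 (beyond the scatter), alters the same amide-type nitrogen, but it exchanges an amino group for a 3-hydroxypropyl chain, not a hydroxymethyl for a difluoromethyl; it shows only that a single change at this part of the core of compound 2 can move the partition coefficient by a modest amount beyond the scatter. Going by the values given here, with no direct precedent, the expectation for compound 3 rests on the counted difference alone and is held loosely.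

Compound 3 is expected to be more lipophilic than compound 2, by an estimated step of a number 0.98 log units higher from compound 2 to compound 3 (beyond the scatter). The estimate for compound 3 in this assay is 4.2, with a range from 3.6 to 4.8.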

Compound 3, partition coefficient: 3.58
For compound 3 the middle estimate is 0.62 log units above the measured one; measured number below the stated range.
By their numbers in this assay, from the lowest: compound 1; then compound 2; then compound 3.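

In this assay, a change on a saturated chain carbon, two bonds along the chain from an amide-type nitrogen, is enough to move the reading: difluoromethyl in place of hydroxymethyl gives a number 0.36 log units higher from compound 2 to compound 3 (beyond the scatter), a modest step, so this chain carbon responds even with the rest of the chain kept. Starting from the amino group, 3,3-difluoropropyl in place of amino gives a number 1.27 log units higher from compound 1 to compound 3 (beyond the scatter), a large step where the 3-hydroxypropyl chain gave only a modest one, so what the chain carries helps set how far the number rises at this amide-type nitrogen. No measurement at hand bears on why the number moves with this exchange.

The compounds shown leave open how the number would respond to an amine or a carboxylic acid on the same chain carbon, or to a longer chain carrying difluoromethyl. They also leave open whether the exchange of hydroxymethyl for difluoromethyl would give a step of similar size elsewhere: it is seen here only once, on this one chain and the shared core.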